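From a Hydroxy Group to a Vinyl Group

The source may hold more compounds than are shown below. What is called first, only, known or untested is meant among the compounds shown, and "the series" means these compounds.

Of the compounds shown here, three sharing one core have been tested in an assay on HEK293 cells for binding affinity to 5-hydroxytryptamine receptor 7 (Homo sapiens), read by radioligand binding, tested at 1 uM; on this read-out lower numbers stand for less inhibition and higher numbers for more inhibition at the one concentration tested (going by the name of the read-out). Compound 1 `CN1CCCN(CCn2ccc3ccc(F)cc32)CC1` gives 60%. Compound 2 `CN1CCCN(CCn2ccc3ccc(Cl)cc32)CC1` gives 85%. Compound 3 `CN1CCCN(CCn2ccc3ccc(O)cc32)CC1` gives 28%, the lowest of the three numbers. The gap to the nearest value is shown by a number 32 percentage points lower from compound 1 to compound 3 (beyond the scatter), and the gap to the furthest by a number 57 percentage points lower from compound 2 to compound 3 (beyond the scatter); each of these swaps one group on an aromatic carbon, and in both cases the hydroxy group gives the lowest number. The comparison between the two halogen compounds adds a number 25 percentage points higher from compound 1 to compound 2 (beyond the scatter).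

Compound 4 `C=Cc1ccc2ccn(CCN3CCCN(C)CC3)c2c1` is not yet measured. It differs from compound 3 in one place: vinyl in place of hydroxy on an aromatic carbon. Among the measured compounds shown here, no measured step involves a vinyl group, so the closest guides are the two steps that introduce a hydroxy group, both of them large and both toward lower inhibition. Taking a number 32 percentage points lower from compound 1 to compound 3 (beyond the scatter) and a number 57 percentage points lower from compound 2 to compound 3 (beyond the scatter) as the relevant steps run in reverse, a rise beyond the scatter in this assay is expected for compound 4, with the step estimated as a number 42 percentage points higher from compound 3 to compound 4 (beyond the scatter). Compound 4 is therefore expected to give about 70%, within a range from 45% to 90%.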

Compound 4, a percentage reported as inhibition, at one concentration (the size of the read-out at that concentration, not a potency): 79%
The estimate for compound 4 lay 9 percentage points below the measured number, within the range that was stated.
By their numbers in this assay, from the lowest: compound 3; then compound 1; then compounds 4 and 2 (each within the scatter of the next).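

This position is not limited to halogens for a high number in this assay: the all-carbon vinyl group gives a number 51 percentage points higher from compound 3 to compound 4 (beyond the scatter), and a number 19 percentage points higher from compound 1 to compound 4 (beyond the scatter). Set against chloro, vinyl gives a number 6 percentage points lower from compound 2 to compound 4 (within the scatter), so these two quite different groups cannot be told apart here, and the low number of compound 3 now stands out as specific to hydroxy among the four groups tested at this position. Hydroxy has 1 hydrogen-bond donor and 1 hydrogen-bond acceptor and vinyl has 0 of each, but nothing available explains why the numbers differ, as no separate measurement bears on the cause.

The compounds shown leave open whether the number depends on the hydrogen-bond count, on the size of the group or on the double bond of vinyl, since hydroxy and vinyl differ in all of these at once. A methoxy group would keep the oxygen without its hydrogen and an ethyl group would keep the two carbons without the double bond, so each would help to separate these features.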